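Amide nitrogen variation on a shared core: compound 4

The source may report more compounds than this note shows. Statements on the series, on what has been measured and on what is new or still open speak of the compounds shown alone.

Compound 1 `Cc1ccc(/C=N/NC(=O)c2oc3nc(-c4cccs4)cc(C(F)(F)F)c3c2N)cc1` gives 19800 nM in a functional assay on HepG2 cells (Homo sapiens) for antiproliferative activity, read by MTT assay; on this read-out higher numbers stand for weaker inhibition and lower numbers for stronger inhibition.
Compound 2 `Nc1c(C(=O)N/N=C/c2ccccc2)oc2nc(-c3cccs3)cc(C(F)(F)F)c12` gives 9900 nM in this assay.
Compound 3 `CCNC(=O)c1oc2nc(-c3cccs3)cc(C(F)(F)F)c2c1N` gives 12100 nM in this assay.

Compound 3 stands second highest of the three numbers; its nearest neighbour is compound 2 and its furthest is compound 1, and both gaps are within the scatter. Compound 4 `Nc1c(C(=O)NC2CCCC2)oc2nc(-c3cccs3)cc(C(F)(F)F)c12` has not yet been measured in this assay. It differs from compound 3 in one place: cyclopentyl in place of ethyl on an amide-type nitrogen. The cyclopentyl enters on an amide-type nitrogen whose other neighbour is the carbonyl carbon.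

Going by the values given here, two measured steps touch the same amide-type nitrogen. The step of a 1.6-fold lower number from compound 1 to compound 3 (0.21 log units; within the scatter) and the step of a 1.2-fold higher number from compound 2 to compound 3 (0.09 log units; within the scatter) both exchange a large group for the ethyl group and both stay within the scatter. The third step, a 2.0-fold lower number from compound 1 to compound 2 (0.30 log units; within the scatter), changes a methyl on an aromatic carbon and is also within the scatter. Among the compounds with values here, no measured step here moves the number beyond the scatter, so no step beyond the scatter is expected for the exchange of ethyl for cyclopentyl either. Compound 4 is therefore expected to give about 11000 nM, with a range from 4500 nM to 28000 nM, which means an expected step of a 1.1-fold lower number from compound 3 to compound 4 (0.04 log units; within the scatter).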

Compound 4, half-maximal inhibitory concentration: 20800 nM
The estimate for compound 4 lay 1.9-fold (0.28 log units) below the measured number; the range from low to high includes it.
By their numbers in this assay, from the lowest: compounds 2, 3, 1 and 4 (each within the scatter of the next, the first and the last beyond it).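

In this assay, cyclopentyl on the amide-type nitrogen gives the first view of a non-aromatic ring at this position, and the exchange with ethyl stays within the scatter (a 1.7-fold higher number from compound 3 to compound 4 (0.24 log units; within the scatter)), as does the exchange with the methyl-bearing group (a 1.1-fold higher number from compound 1 to compound 4 (0.02 log units; within the scatter)). Going by these compounds alone, the only step on this nitrogen that passes beyond the scatter is a modest one (a 2.1-fold higher number from compound 2 to compound 4 (0.32 log units; beyond the scatter)), in which cyclopentyl takes the place of the group with the unsubstituted six-membered aromatic ring, so a change at this position can now be told apart from the scatter, though only just and in only one pair. No supporting information explains this step.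

Going by these compounds, whether the ring matters, or only the size of the group, stays open: a pentyl chain, a cyclohexyl ring or a cyclopentyl ring bearing an amine or a carboxylic acid on this nitrogen could separate the two. The shared core is also the same in all four compounds, so the result says nothing about whether the cyclopentyl exchange would behave alike on a core without the trifluoromethyl group.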